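Toward a 2,6-Dimethylphenyl Analogue of Compound 2

A few compounds are considered here, and "the series" means these few. Any claim that something is new, unique, unknown or untested is made for them only; others in the source may bear on it.

For the measured compounds named here, compound 2 `COc1cc2c(Oc3ccc(NC(=O)c4cn(-c5ccccc5C)nn4)cc3F)ccnc2cc1OCCCN1CCN(C)CC1` gives 1430 nM in a functional assay on HT-29 cells (Homo sapiens) for cytotoxicity, read by MTT assay, with a stated time of 72 h (a lower number here means a stronger inhibitor, a higher number a weaker inhibitor), the lowest of the two numbers known so far; its nearest neighbour, compound 1 `COc1cc2c(Oc3ccc(NC(=O)c4cn(-c5c(C)cccc5C)nn4)cc3F)ccnc2cc1OCCCN1CCCCC1`, gives 3690 nM in this assay, a gap beyond the usual scatter. Compound 3 `COc1cc2c(Oc3ccc(NC(=O)c4cn(-c5c(C)cccc5C)nn4)cc3F)ccnc2cc1OCCCN1CCN(C)CC1` carries methyl in place of hydrogen on an aromatic carbon, so that 2-methylphenyl becomes 2,6-dimethylphenyl. Going by the values given here, compound 1 also bears the 2,6-dimethylphenyl group, yet it differs from compound 2 in a second place as well, so no single step isolates this change. Compound 3 is therefore expected to show only a modest rise in the number, a step of a 1.7-fold higher number from compound 2 to compound 3 (0.24 log units; within the scatter), with an estimate of 2500 nM and a range from 900 nM to 7000 nM.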

Compound 3, half-maximal inhibitory concentration: 2170 nM
Estimate against measurement, compound 3: 1.2-fold (0.06 log units) above; the measured number falls inside the stated range.
By their numbers in this assay, from the lowest: compounds 2, 3 and 1 (each within the scatter of the next, the first and the last beyond it).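

In this assay methyl in place of hydrogen on the aromatic carbon gives a 1.5-fold higher number from compound 2 to compound 3 (0.18 log units; within the scatter) and so leaves 2-methylphenyl and 2,6-dimethylphenyl indistinguishable here. For the compounds shown here, the single change of piperidin-1-yl to 4-methylpiperazin-1-yl gives a 1.7-fold lower number from compound 1 to compound 3 (0.23 log units; within the scatter) and also stays within the scatter, so the wider gap between compound 1 and compound 2 now divides into two steps, neither distinct alone. No measurement given here explains these results. Going by these compounds, whether chlorine or an ethyl group on that same carbon would give a step beyond the scatter remains open. So does the effect of morpholin-4-yl on the chain.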